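The source may hold more compounds than are shown below. What is called first, only, known or untested is meant among the compounds shown, and "the series" means these compounds.

Going by the values given here, compound 1 `COC(=O)c1ccc(OCCCCOc2ccc(C(=O)CC3CCCC3)c(O)c2C)cc1` has in an assay on HEK293 cells for positive allosteric modulation of metabotropic glutamate receptor 3 (Rattus norvegicus), read by thallium flux, with a stated time of 2.5 min (a lower number here means that less compound is needed, a higher number that more compound is needed for the effect), only the entry "not determined" (no result reported), with no number behind it, so compound 2 `Cc1c(OCCCCOCOc2ccc(C(=O)O)cc2)ccc(C(=O)CC2CCCC2)c1O` is the only compound with a number, and in this assay compound 2 gives 1910 nM. Compound 3 `Cc1c(OCCCCOc2ccc(C(=O)O)cc2F)ccc(C(=O)CC2CCCC2)c1O` differs from compound 2 in one place: 4-carboxy-2-fluorophenyl in place of (4-carboxyphenoxy)methyl on an oxygen on a saturated carbon. Among the compounds with values here, no pair of measured compounds shows how a change of this kind moves the number, so nothing earlier gives the size of this step. Without such a guide, the step is expected to stay within the usual scatter, a 1.0-fold lower number from compound 2 to compound 3 (0.00 log units; within the scatter), with no clear direction. Compound 3 is therefore estimated to give 1900 nM, in a range from 600 nM to 6000 nM.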

Compound 3, half-maximal effective concentration: > 10000 nM
Compound 3: a limit, no number; the forecaster's own chance of this, stated with the estimate: 15%; middle value at least 5.2-fold (0.72 log units) away from the limit.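

In this assay, the change on this oxygen gives an at least 5.2-fold higher number from compound 2 to compound 3 (0.71 log units; beyond the scatter), so this end of the molecule clearly matters for the read-out. Compound 3 gives > 10000 nM, which is a limit of the assay and not a number. Two things change together in this step: a fluorine enters on the ring, and the link from the chain to that ring becomes shorter.

The compounds shown do not separate these two changes. Going by these compounds, it also remains open how a 4-carboxyphenyl without fluorine, or an amide in place of the carboxylic acid, would read.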